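Swapping Azido for Hydroxy on a Nucleoside Core

The compounds below may be only part of what the source reports. "The series", "measured", "known", "first", "only" and "open" are said of these compounds alone.

Three nucleoside analogues have been tested in an ADME assay on CCRF-CEM cells (Homo sapiens) for cytotoxicity, read by trypan blue exclusion, with a stated time of 6 days; on this read-out higher numbers stand for lower toxicity in this test and lower numbers for higher toxicity in this test. Compound 1 `C=C(OCC)c1nc(N)nc2c1ncn2[C@@H]1O[C@H](CO)[C@@H](O)[C@@]1(C)O` gives > 100000 nM; this is a limit of the assay, not a measured number. Compound 2 `C[C@@]1(O)[C@H](O)[C@@H](CO)O[C@H]1n1cnc2c(N)nc(N=[N+]=[N-])nc21` gives > 100000 nM, again only a limit. Compound 3 `COc1nc(OC)c2ncn([C@@H]3O[C@H](CO)[C@@H](O)[C@@]3(C)O)c2n1` gives > 100000 nM, also a limit. Within the data shown here, compound 2 therefore stands where every other compound stands: all three values rest at the limit of > 100000 nM in this assay, at which 3 of the 3 values shown sit, so no ordering among them can be read off, and no step between measured compounds is available.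

The next compound, compound 4 `C[C@@]1(O)[C@H](O)[C@@H](CO)O[C@H]1n1cnc2c(N)nc(O)nc21`, differs from compound 2 by hydroxy in place of azido on an aromatic carbon. With nothing but three limits in hand, the expectation for the step from compound 2 to compound 4 is no change beyond the scatter, expressed as a step that the limit leaves unreadable from compound 2 to compound 4. Compound 4 is expected to give about 150000 nM in this assay, within a range from 50000 nM to 500000 nM, most likely reported again as a limit rather than a number.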

Compound 4, half-maximal cytotoxic concentration: > 100000 nM
Compound 4: a limit, no number; the forecaster's own chance of this, stated with the estimate: 85%; the middle value lies beyond the limit too.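

Compound 2 and compound 4 both give only a limit, so swapping azido for hydroxy yields no readable step: the limit of > 100000 nM in this assay, at which 4 of the 4 values shown sit.

The compounds shown leave open how these nucleosides rank in this assay, and whether this swap changes the result at all.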